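This account rests on a few compounds, and the source may have more. Where it says the series, first, only, none or still open, it means among the compounds named here.

Compound 1 `CCCCC(=O)Nc1ccc(C2=NNC(=O)CC2)cc1` gives in a functional assay for inhibition, with Homo sapiens as the target (a lower number here means that less compound is needed, a higher number that more compound is needed for the effect), 2.64 ug/mL.
Compound 2 `CN1N=C(c2ccc(N)cc2)CCC1=O` gives in this assay only a limit of the assay, > 46.4 ug/mL.

Within the data shown here, compound 1 is the only one of the two with a measured number in this assay; the other result is the limit of > 46.4 ug/mL in this assay, at which 1 of the 2 values shown sits, so no step between measured compounds can be read from these data, and the pair says only that compound 1 reaches a number where compound 2 does not.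

Compound 3 `C=CCNCC(=O)Nc1ccc(C2=NNC(=O)CC2)cc1` is not yet measured. It differs from compound 1 in one place: allylamino in place of propyl on a saturated chain carbon bound to a carbonyl carbon. The shared core and the amide attached to it stay as they are; only the chain on the saturated chain carbon bound to the carbonyl carbon changes, from propyl to allylamino.

Among the measured compounds shown here, with no measured step to lean on, the expectation rests on compound 1 alone. The step from compound 1 to compound 3 is expected to be small, a 1.5-fold higher number from compound 1 to compound 3 (0.18 log units; within the scatter), within or close to the scatter, with a slight lean toward a higher number. Compound 3 is therefore estimated at 4 ug/mL, in a range from 1.3 ug/mL to 13 ug/mL.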

Compound 3, half-maximal effective concentration: about 21.5 ug/mL
Compound 3: the middle estimate sits 5.4-fold (0.73 log units) below what was measured; the whole stated range lies below it.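

In this assay, allylamino in place of propyl on a saturated chain carbon bound to a carbonyl carbon gives an 8.1-fold higher number from compound 1 to compound 3 (0.91 log units; beyond the scatter), so the result at this place depends on what the chain carries, even with the shared core and the amide unchanged. Among these compounds, compound 1 alone could not show this, and compound 3 adds the second number and with it the one readable step, which lies beyond the scatter and comes from a change in this chain alone. No step to compound 2 can be read, as its result is a limit of the assay and not a number: the limit of > 46.4 ug/mL in this assay, at which 1 of the 3 values shown sits.

The compounds shown leave open whether the higher number goes with the chain nitrogen or with the double bond, which enter together in allylamino; a propylamino group would carry the nitrogen without the double bond, and a butenyl chain the double bond without the nitrogen. They also leave open how a longer alkyl chain or a carboxylic acid at this place would read in this assay.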